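The source may report more compounds than this note shows. Statements on the series, on what has been measured and on what is new or still open speak of the compounds shown alone.

Measured in an ADME assay on microsomes from liver (Homo sapiens) for metabolic stability, read by LC-MS, using NADPH, with stated times of 5 min and 30 min, tested at 1 uM; on this read-out higher numbers stand for fast clearance and lower numbers for slow clearance:

- Compound 1 `O=C(Nc1ccccc1)c1cnc(NCc2c(F)ccc3c2CCO3)n2cnnc12`: 14 mL.min-1.g-1
- Compound 2 `Fc1ccc2c(c1CNc1ncc(Oc3ccccc3)c3nncn13)CCO2`: 18 mL.min-1.g-1
- Compound 3 `CC(=O)N1CCC(c2cnc(NCc3c(F)ccc4c3CCO4)c3cn[nH]c(=O)c23)CC1`: 207 mL.min-1.g-1

Compound 3 has the highest of the three numbers, and the gap to each of the other two lies beyond the scatter of repeat measurements. Compound 4 `CNC(=O)c1cc(-c2cnc(NCc3c(F)ccc4c3CCO4)c3cn[nH]c(=O)c23)n(C)n1` keeps the core of compound 3 and changes one group, 1-methyl-3-(methylcarbamoyl)-1H-pyrazol-5-yl in place of 1-acetylpiperidin-4-yl on an aromatic carbon.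

Among the measured compounds shown here, only one measured step bears on this swap, and only loosely. It exchanges phenylcarbamoyl for phenoxy on a core unlike that of compound 3, and it amounts to a 1.3-fold higher number from compound 1 to compound 2 (0.11 log units; within the scatter). For the measured compounds named here, no measured step starts from compound 3, so the effect of changing its group is unknown. Compound 3 at 207 mL.min-1.g-1 sits at the top of the range seen so far, and compound 2 at 18 mL.min-1.g-1 shows that much lower numbers occur, although on another core. A move down in this assay therefore seems likelier than a move up, with wide uncertainty. The expected step is a 3.0-fold lower number from compound 3 to compound 4 (0.47 log units; beyond the scatter). For compound 4 the estimated value is 70 mL.min-1.g-1, with an expected range of 20 mL.min-1.g-1 to 220 mL.min-1.g-1.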

Compound 4, intrinsic clearance in microsomes: < 3 mL.min-1.g-1
Compound 4 was reported as a limit; the forecaster's own chance of this, stated with the estimate: 5%; at least 23-fold (1.36 log units) between middle value and limit.
By their numbers in this assay, from the lowest: compounds 1 and 2 (each within the scatter of the next); then compound 3. At a limit, below all of these: compound 4.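

In this assay, replacing 1-acetylpiperidin-4-yl with 1-methyl-3-(methylcarbamoyl)-1H-pyrazol-5-yl gives an at least 69-fold lower number from compound 3 to compound 4 (1.83 log units; beyond the scatter), a large step that shows how far the read-out can move with the group at this place on the core of compound 3. The earlier compounds shown here offered a single step, on a different core and within the scatter, and gave no sign that one change on an aromatic carbon could shift the number this far. Going by these compounds, compound 4 gives a limit and not a number, so the full size of the step stays unknown: the limit of < 3 mL.min-1.g-1 in this assay, at which 1 of the 4 values shown sits.

This single swap changes the ring and its substituents together, so the data cannot say whether the five-membered aromatic ring, the methylcarbamoyl group or the two in combination account for the step. On these data alone, it also remains open how this assay would respond at this place to a piperidine ring carrying methylcarbamoyl in place of acetyl, to a morpholine ring or to a carboxylic acid, and whether the step would carry over to the cores of compound 1 and compound 2.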